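The source may report more compounds than this note shows. Statements on the series, on what has been measured and on what is new or still open speak of the compounds shown alone.

Compounds measured so far:
compound 1 `CC1CCN(C2CCN(S(=O)(=O)c3cccc(-c4ccccc4C(F)(F)F)c3)CC2)CC1` gives 0.617 h;
compound 2 `CC1CCN(C2CCN(S(=O)(=O)c3cccc(Br)c3)CC2)CC1` gives 0.217 h;
compound 3 `COc1ccccc1-c1cccc(S(=O)(=O)N2CCC(N3CCC(C)CC3)CC2)c1` gives 0.25 h.

These numbers come from an ADME assay on S9 fraction from liver (Mus musculus, strain ICR/CD-1) for metabolic stability, read by LC-MS, using NADPH, with a stated time of 5 min, tested at 2 uM; on this read-out higher numbers stand for a longer-lived compound and lower numbers for a shorter-lived compound. Compound 1 stands highest of the three, with compound 3 nearest to it and compound 2 furthest away. The step to compound 4 `CC1CCN(C2CCN(S(=O)(=O)c3cccc(-c4ccccc4F)c3)CC2)CC1` is fluoro in place of trifluoromethyl on an aromatic carbon. For the measured compounds named here, two measured steps touch the same part of compound 1: the step of a 2.5-fold lower number from compound 1 to compound 3 (0.39 log units; beyond the scatter) and the step of a 2.8-fold lower number from compound 1 to compound 2 (0.45 log units; beyond the scatter). Each of those changes at that spot gave a lower number, and neither step was large. A modest drop in this assay is therefore expected for compound 4 as well. Compound 4 is estimated at 0.3 h, in a range from 0.15 h to 0.6 h, which is expected to mean a step of a 2.1-fold lower number from compound 1 to compound 4 (0.31 log units; beyond the scatter).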

Compound 4, half-life: 0.283 h
Compound 4: middle estimate off by 1.1-fold (0.03 log units), on the high side; low and high end bracket the measured number.
By their numbers in this assay, from the lowest: compounds 2, 3 and 4 (each within the scatter of the next); then compound 1.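

In this assay, fluoro joins methoxy and bromo in falling short of the compound carrying 2-(trifluoromethyl)phenyl (a 2.2-fold lower number from compound 1 to compound 4 (0.34 log units; beyond the scatter)), so compound 1 alone stands apart among these four. Compound 4 cannot be told apart from the other two (a 1.1-fold higher number from compound 3 to compound 4 (0.05 log units; within the scatter); a 1.3-fold higher number from compound 2 to compound 4 (0.12 log units; within the scatter)), so swapping fluoro for methoxy or 2-fluorophenyl for bromo makes no readable difference. No measured evidence on the cause is available. As far as these compounds go, it remains open whether another group on this aromatic carbon, such as chloro, methyl or nitrile, would match trifluoromethyl.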